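The compounds below may be only part of what the source reports. "The series", "measured", "known", "first", "only" and "open" are said of these compounds alone.

Compound 1 `COc1cc(CNC(=O)/C=C/c2ccccc2OCc2nc(C)c(C)nc2C)ccc1O` and compound 2 `COc1cc(CNC(=O)/C=C/c2ccccc2OCc2nc(C)c(C)nc2C)ccc1OCc1nc(C)c(C)nc1C` share a core and differ in one place, the change being ((3,5,6-trimethylpyrazin-2-yl)methyl in place of hydrogen on an oxygen on an aromatic ring). In a functional assay on SH-SY5Y cells (Homo sapiens) for cytotoxicity, read by MTT assay, with stated times of 24 h and 4 h (a lower number here means that less compound is needed, a higher number that more compound is needed for the effect), compound 1 gives 12000 nM, while compound 2 gives 6280 nM. That change produced a 1.9-fold lower number from compound 1 to compound 2 (0.28 log units; within the scatter), a shift too small to be read as a real difference.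

Compound 3 `COc1cccc(/C=C/C(=O)NCc2ccc(O)c(OC)c2)c1` has a different core; how the two cores differ is not broken down here. In this assay compound 3 gives 5240 nM, which sits close to the number of compound 2 but stands clearly apart from that of compound 1.

Compound 4 `COc1cccc(/C=C/C(=O)NCc2ccc(OCc3nc(C)c(C)nc3C)c(OC)c2)c1` is built from compound 3 by the same change, ((3,5,6-trimethylpyrazin-2-yl)methyl in place of hydrogen on an oxygen on an aromatic ring), made at a place whose surroundings read identically. Within the data shown here, since the only precedent for this change, a 1.9-fold lower number from compound 1 to compound 2 (0.28 log units; within the scatter), stayed within the scatter, a similarly modest move is expected here, namely a 1.5-fold lower number from compound 3 to compound 4 (0.18 log units; within the scatter). Compound 4 is therefore estimated to give about 3500 nM in this assay, with a plausible range from 1500 nM to 9000 nM for compound 4.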

Compound 4, half-maximal effective concentration: 4320 nM
Estimate against measurement, compound 4: 1.2-fold (0.09 log units) below; the measured number falls inside the stated range.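

In this assay the change produced a 1.2-fold lower number from compound 3 to compound 4 (0.08 log units; within the scatter), so on the core of compound 3, as on the core of compound 1, the step cannot be told apart from repeat measurements. Set side by side, the two steps do not differ, and the change reads the same on both cores: the same change on two cores in this assay, a 1.9-fold lower number (0.28 log units; within the scatter) from compound 1 to compound 2 and a 1.2-fold lower number (0.08 log units; within the scatter) from compound 3 to compound 4, 1.6-fold (0.20 log units) apart, within the scatter of two such steps. This shows that across these two pairs the swap of hydrogen for (3,5,6-trimethylpyrazin-2-yl)methyl carries over without a visible shift, but it does not show a real effect of the group in either direction, and two pairs say nothing about cores beyond these.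

The compounds shown leave open whether a different group on that same oxygen, such as a longer alkyl chain, a benzyl group or a chain ending in an amine or a carboxylic acid, would move the number beyond the scatter. They also leave open how a pyrazinylmethyl group without its three methyl groups would behave.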